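Removing the Nitrogen Methyl from Compound 1

The source may hold more compounds than are shown below. What is called first, only, known or untested is meant among the compounds shown, and "the series" means these compounds.

Compound 1, `Cc1sc(-c2ccccc2)cc1-c1cc(C(N)=O)nn1C`, was tested in an assay on isolated protein for inhibition of Group 10 secretory phospholipase A2 (Homo sapiens), with a stated time of 30 min (a higher number here means a weaker inhibitor, a lower number a stronger inhibitor), where compound 1 gives 1200 nM. Its closest measured relative is compound 2, `Cc1cc(-c2cc(C(N)=O)nn2C)c(C)s1`, and in this assay compound 2 gives 851 nM. Among the compounds with values here, the only measured step, a 1.4-fold lower number from compound 1 to compound 2 (0.15 log units; within the scatter), swaps a group on a ring carbon, so the two numbers lie within the usual scatter of each other.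

Compound 3, `Cc1sc(-c2ccccc2)cc1-c1cc(C(N)=O)n[nH]1`, has not yet been measured. It differs from compound 1 by hydrogen in place of methyl on an aromatic nitrogen. Within the data shown here, no measured step touches this aromatic nitrogen, so the one step in hand gives no direct guide, and the smallest change seen so far stayed within the scatter. On that basis the step of no change at the digits printed from compound 1 to compound 3 (within the scatter) is expected to be no larger than the scatter in either direction. Compound 3 is therefore estimated at 1200 nM, with a range from 400 nM to 3600 nM.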

Compound 3, half-maximal inhibitory concentration: 347 nM
Estimate against measurement, compound 3: 3.5-fold (0.54 log units) above; the measured number lies below the stated range.
By their numbers in this assay, from the lowest: compound 3; then compounds 2 and 1 (each within the scatter of the next).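

In this assay there is a 3.5-fold lower number from compound 1 to compound 3 (0.54 log units; beyond the scatter) when hydrogen takes the place of methyl on an aromatic nitrogen, a step beyond the scatter. This shows that the aromatic nitrogen is a place where removing a single carbon can shift the number measurably, which the swap of phenyl for methyl on a ring carbon, within the scatter between compounds 1 and 2, gave no sign of. Nothing measured here explains why the number falls with this change.

From the compounds shown here alone, whether an ethyl group or a longer chain on this nitrogen would raise the number further above that of compound 1 remains open. Going by these compounds, it is also open whether the same change would give a similar step on the core of compound 2.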